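Amino to methoxy on a stilbene core: next step

The source may hold more compounds than are shown below. What is called first, only, known or untested is meant among the compounds shown, and "the series" means these compounds.

Compound 1 `Nc1ccccc1/C=C/c1cccc(O)c1`: 20 ug/mL
Compound 2 `Nc1cccc(/C=C/c2ccccc2O)c1`: 96 ug/mL
Compound 3 `COc1cccc(/C=C/c2ccccc2O)c1`: 20 ug/mL

In an ADME assay on HEK293 cells (Homo sapiens) for inhibition, read by MTT assay, with a stated time of 2 days (on this read-out lower numbers stand for stronger inhibition and higher numbers for weaker inhibition), compound 1 gives 20 ug/mL, compound 2 gives 96 ug/mL and compound 3 gives 20 ug/mL. Compound 1 and compound 3 stand level at the digits printed; compound 2 sits higher than both. Compound 1 and compound 2 share the same atoms joined differently, and the difference between the two cores is not broken down here. Compound 3 is reached from compound 2 by methoxy in place of amino on an aromatic carbon, and this gave a 4.8-fold lower number from compound 2 to compound 3 (0.68 log units; beyond the scatter). Compound 4 `COc1ccccc1/C=C/c1cccc(O)c1` is not yet measured in this assay. It is reached from compound 1 by methoxy in place of amino on an aromatic carbon, the same kind of change, but the group now sits ortho to a group of 9 heavy atoms rather than meta. Among the compounds with values here, compound 4 is expected to show a 2.0-fold lower number from compound 1 to compound 4 (0.30 log units; within the scatter), a step smaller than the one from compound 2 to compound 3 because compound 1 already gives 20 ug/mL. Compound 4 is estimated at 10 ug/mL, between 4 ug/mL and 40 ug/mL.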

Compound 4, half-maximal inhibitory concentration: 24 ug/mL
Compound 4: middle estimate off by 2.4-fold (0.38 log units), on the low side; the range from low to high includes it.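

In this assay methoxy in place of amino on an aromatic carbon gave a 1.2-fold higher number from compound 1 to compound 4 (0.08 log units; within the scatter) and so no readable difference on the core of compound 1. The same change therefore does not carry over at the same size between the two cores: the same change on two cores in this assay, a 4.8-fold lower number (0.68 log units; beyond the scatter) from compound 2 to compound 3 and a 1.2-fold higher number (0.08 log units; within the scatter) from compound 1 to compound 4, 5.8-fold (0.76 log units) apart, beyond the scatter of two such steps. This shows that, for these two pairs, the size of the step depends on the core, but it does not show which feature of the cores sets it, and two pairs give no rule for any further core.

The compounds shown leave open how a fluorine or an ethoxy in that place would read on either core. They also leave open whether the gap between the cores would hold for such groups.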